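From methyl to nitro: compound 2 and compound 3

The compounds below may be only part of what the source reports. "The series", "measured", "known", "first", "only" and "open" are said of these compounds alone.

Compound 1 `CC(C)(C)NCc1c(C(=O)O)nn(-c2ccccc2)c1-c1ccc([N+](=O)[O-])cc1`: > 634000 nM (a limit)
Compound 2 `Cc1ccc(-c2c(CNC(C)(C)C)c(C(=O)O)nn2-c2ccc(Cl)cc2)cc1`: > 629000 nM (a limit)

Both entries come from a functional assay on OVCAR-3 cells (Homo sapiens) for inhibition, read by sulforhodamine B assay, with a stated time of 48 h (a lower number here means a stronger inhibitor of growth, a higher number a weaker inhibitor of growth), and each is a limit of the assay, not a number. Compound 2 therefore stands only at its limit of > 629000 nM. Compound 3 `CC(C)(C)NCc1c(C(=O)O)nn(-c2ccc(Cl)cc2)c1-c1ccc([N+](=O)[O-])cc1` has nitro in place of methyl on an aromatic carbon, para to a large group, so 4-methylphenyl becomes 4-nitrophenyl (nitro in place of methyl on an aromatic carbon). Within the data shown here, no measured step shows what such a swap does here, so no change beyond the usual scatter is expected in this assay. The expected size is an at least 1.0-fold lower number from compound 2 to compound 3 (0.03 log units; that floor lies within the scatter). Compound 3 is estimated at about 583000 nM, with an expected range of 300000 nM to 700000 nM.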

Compound 3, concentration for 50% growth inhibition: 162000 nM
Compound 3: the middle estimate sits 3.6-fold (0.56 log units) above what was measured; measured number outside the range, below it.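

In this assay, 4-nitrophenyl in place of 4-methylphenyl gives an at least 3.8-fold lower number from compound 2 to compound 3 (0.58 log units; beyond the scatter), so this position can change growth inhibition. Chloro in place of hydrogen on an aromatic carbon, with the 4-nitrophenyl kept, gives an at least 3.9-fold lower number from compound 1 to compound 3 (0.59 log units; beyond the scatter), so among these compounds a measured number appears only where nitro and chloro occur together. Both steps are only floors, since compound 2 and compound 1 stand at limits of the assay: the limit of > 629000 nM in this assay, at which 1 of the 3 values shown sits; the limit of > 634000 nM in this assay, at which 1 of the 3 values shown sits.

On these data alone, what a nitrile or a methoxy group would do at this position stays open.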